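Lengthening the chain between the amide and the amine

The compounds below may be only part of what the source reports. "The series", "measured", "known", "first", "only" and "open" are said of these compounds alone.

The compounds share one core and differ only in the group on the amide nitrogen. In a functional assay on the whole organism for inhibition of sodium-dependent dopamine transporter (Mus musculus) (on this read-out lower numbers stand for an effect already at smaller amounts and higher numbers for an effect only at larger amounts of compound), compound 2 `CCCCOC(=O)Nc1cccc2c1CN(C)CC2c1ccccc1` gives 12 mg/kg. Compound 1 `CCNC(=O)Nc1cccc2c1CN(C)CC2c1ccccc1` gives only a limit of the assay, > 80 mg/kg, not a number. Compound 3 `CCNCC(=O)Nc1cccc2c1CN(C)CC2c1ccccc1` gives about 60 mg/kg and thus stands highest of the two numbers shown, separated from compound 2 by the step of a 5.0-fold higher number from compound 2 to compound 3 (0.70 log units; beyond the scatter). Compound 4 `CCNCCC(=O)Nc1cccc2c1CN(C)CC2c1ccccc1` carries the change ((ethylamino)methyl in place of ethylamino on a saturated chain carbon bound to a carbonyl carbon). For the measured compounds named here, the only measured step of the same kind is an at least 1.3-fold lower number from compound 1 to compound 3 (0.12 log units; that floor lies within the scatter), which lies within the scatter at its floor, though that exchange sat on a carbonyl carbon rather than on a saturated chain carbon bound to a carbonyl carbon, and it started from a limit. With only this to lean on, no shift beyond the scatter is expected from compound 3 to compound 4. The expected value for compound 4 in this assay is 50 mg/kg, within 20 mg/kg to 120 mg/kg. This estimate means an expected step of a 1.2-fold lower number from compound 3 to compound 4 (0.08 log units; within the scatter).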

Compound 4, dose for half-maximal effect: 190 mg/kg
Estimate against measurement, compound 4: 3.8-fold (0.58 log units) below; measured number outside the range, above it.
By their numbers in this assay, from the lowest: compound 2; then compound 3; then compound 4.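

Adding one carbon to the chain on the carbonyl carbon, turning (ethylamino)methyl into 2-(ethylamino)ethyl, weakens the effect in this assay: a 3.2-fold higher number from compound 3 to compound 4 (0.50 log units; beyond the scatter). For the compounds shown here, the one earlier step of this kind started from a limit and its floor lay within the scatter, so this is the first readable sign that chain length matters at this position, and the distance from butoxy on the carbonyl carbon is larger still: a 16-fold higher number from compound 2 to compound 4 (1.20 log units; beyond the scatter). Compound 1 has only a limit, so its step to compound 4 cannot be read: the limit of > 80 mg/kg in this assay, at which 1 of the 4 values shown sits.

The compounds shown do not tell whether a still longer chain, such as 3-(ethylamino)propyl, would raise the number further. They also leave open whether a dimethylamino group in place of the ethylamino end would change the picture.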